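Dimethylamino for trifluoromethoxy: what to expect of compound 4

The compounds below may be only part of what the source reports. "The series", "measured", "known", "first", "only" and "open" are said of these compounds alone.

In a functional assay on MCF7 cells (Homo sapiens) for inhibition, read by sulforhodamine B assay (a lower number here means a stronger inhibitor of growth, a higher number a weaker inhibitor of growth), compound 3 (`Oc1cccc2[nH]c(-c3ccc(-c4ccc(-c5ccc(OC(F)(F)F)cc5)cc4)cc3)nc12`) gives 2210 nM. This lies within the scatter of the other two measured compounds: compound 2 (`Oc1cccc2[nH]c(-c3ccc(-c4ccc(-c5ccc(C(F)(F)F)cc5)cc4)cc3)nc12`) gives 2310 nM and compound 1 (`Cc1ccc2[nH]c(-c3ccc(-c4ccc(-c5ccc(N(C)C)cc5)cc4)cc3)nc2c1`) gives 3130 nM. Compound 4 (`CN(C)c1ccc(-c2ccc(-c3ccc(-c4nc5c(O)cccc5[nH]4)cc3)cc2)cc1`) has dimethylamino in place of trifluoromethoxy on an aromatic carbon, para to a large group: dimethylamino in place of trifluoromethoxy on an aromatic carbon.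

For the measured compounds named here, the one measured step at this place is a 1.0-fold lower number from compound 2 to compound 3 (0.02 log units; within the scatter), which stays within the scatter, but it does not involve dimethylamino. Compound 1 does carry 4-(dimethylamino)phenyl, on a different core, and its 3130 nM stands within the scatter of compound 3. Going by the values given here, no measured step isolates dimethylamino on the core of compound 3, so this expectation remains weakly supported. In this assay, no step beyond the scatter is expected. The expected step is a 1.1-fold higher number from compound 3 to compound 4 (0.05 log units; within the scatter). For compound 4 the estimated value is 2500 nM, with an expected range of 1200 nM to 5200 nM.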

Compound 4, concentration for 50% growth inhibition: 2310 nM
Beside the measured number, compound 4's estimate is 1.1-fold (0.03 log units) above it; measured number inside the range.
By their numbers in this assay, from the lowest: compounds 3, 2, 4 and 1 (each within the scatter of the next).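

In this assay, the change to dimethylamino on the shared core is a 1.0-fold higher number from compound 3 to compound 4 (0.02 log units; within the scatter), and the change from trifluoromethyl is no change at the digits printed from compound 2 to compound 4 (within the scatter), so all three groups at this place now read alike. With 4-(dimethylamino)phenyl held constant, the exchange of benzimidazole groups gives a 1.4-fold lower number from compound 1 to compound 4 (0.13 log units; within the scatter), which adds a comparison of this group on two cores that also stays within the scatter. No measurement on hand offers an explanation for these results.

Going by these compounds, whether a carboxylic acid, a primary amine or a longer alkyl chain at this place would also stay within the scatter of compound 4 remains open. Also open, on these data alone, is whether any replacement at this position can move the number in this assay beyond the scatter.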